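This account rests on a few compounds, and the source may have more. Where it says the series, first, only, none or still open, it means among the compounds named here.

Measured in an ADME assay on Huh-7 cells (Homo sapiens) for cytotoxicity, with a stated time of 72 h (a higher number here means that more compound is tolerated, a lower number that less compound is tolerated), each value a limit of the assay:
- compound 1 `CC(C)(C)CCn1nc(-c2cccs2)c(O)c(C2=NS(=O)(=O)c3cc(NS(C)(=O)=O)ccc3N2)c1=O`: > 1000 nM
- compound 2 `CCCC(C)n1nc(-c2cccs2)c(O)c(C2=NS(=O)(=O)c3cc(NS(C)(=O)=O)ccc3N2)c1=O`: > 33000 nM
- compound 3 `CC(C)Cn1nc(-c2cccs2)c(O)c(C2=NS(=O)(=O)c3cc(NS(C)(=O)=O)ccc3N2)c1=O`: > 1000 nM

Compound 3 has only a limit, > 1000 nM. The two other values are limits too, so it cannot be ranked against compound 1 or compound 2. They fall at two limits: the limit of > 1000 nM in this assay, at which 2 of the 3 values shown sit, and (the limit of > 33000 nM in this assay, at which 1 of the 3 values shown sits).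

Compound 4 `CS(=O)(=O)Nc1ccc2c(c1)S(=O)(=O)N=C(c1c(O)c(-c3cccs3)nn(CC3CC3)c1=O)N2` differs from compound 3 as follows: cyclopropyl in place of isopropyl on a saturated chain carbon bound to an aromatic nitrogen. In other words, cyclopropyl stands in place of isopropyl on a saturated chain carbon bound to an aromatic nitrogen, which also reads as isobutyl to cyclopropylmethyl.

Two measured steps change this same group: a step that the two limits leave unreadable from compound 1 to compound 3 and a step that the two limits leave unreadable from compound 2 to compound 3. A third, a step that the two limits leave unreadable from compound 1 to compound 2, changes the whole substituent on the aromatic nitrogen. None of them has a readable size, and none shows a numerical value in this assay for this group.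

No shift beyond the scatter is therefore expected, and compound 4 is expected to be reported as a limit as well. The expected change, a step that the limit leaves unreadable from compound 3 to compound 4, is an estimate that carries little weight. Compound 4 is estimated at 5000 nM, with an expected range of 1000 nM to 40000 nM.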

Compound 4, half-maximal cytotoxic concentration: > 1000 nM
Compound 4 was reported as a limit; the forecaster's own chance of this, stated with the estimate: 90%; the middle value lies beyond the limit too.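

Compound 4 is reported only as a limit, > 1000 nM, in this assay. Going by these compounds alone, compound 1, compound 2 and compound 3 are limits too, so no step to compound 4 can be read. The compounds shown leave open whether changing the substituent on the aromatic nitrogen shifts tolerance at all.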